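Trimming an oxime ether side group on a shared core

The source may hold more compounds than are shown below. What is called first, only, known or untested is meant among the compounds shown, and "the series" means these compounds.

Compound 1 `Cc1noc(-c2ccccc2NCC2=NCCN2)n1` in a functional assay for activation of Alpha-1B adrenergic receptor (Homo sapiens), read by calcium flux (on this read-out higher numbers stand for an effect only at larger amounts of compound and lower numbers for an effect already at smaller amounts), gives < 5020 nM, which is a limit of the assay and not a number. Compound 2 `Cc1nc(-c2ccccc2NCC2=NCCN2)no1` in this assay gives 676 nM. Compound 3 `CO/N=C(\C)c1ccccc1NCC1=NCCN1` in this assay gives < 5020 nM, again a limit rather than a number.

Compound 3 therefore stands without a fixed position on the numbers shown: its value and that of compound 1 both sit at the same limit (the limit of < 5020 nM in this assay, at which 2 of the 3 values shown sit), and only compound 2 carries a measured number. Among the steps between the measured compounds, a step that the limit leaves unreadable from compound 1 to compound 2, a step that the two limits leave unreadable from compound 1 to compound 3 and a step that the limit leaves unreadable from compound 2 to compound 3 all remain unreadable because of the limits, so none of them gives a usable size.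

Compound 4 `CO/N=C/c1ccccc1NCC1=NCCN1` differs from compound 3 by a group of 4 heavy atoms (2 carbon, 1 nitrogen, 1 oxygen; no ring) in place of a group of 5 heavy atoms (3 carbon, 1 nitrogen, 1 oxygen; no ring), on an aromatic carbon. Going by the values given here, no measured step touches this kind of change, and the anchor compound 3 itself is known only as a limit, so the size of the step in this assay cannot be anticipated from the data; no direction beyond the scatter is claimed.

On that thin basis compound 4 is estimated at 1000 nM, with a range from 150 nM to 5000 nM, and the step that the limit leaves unreadable from compound 3 to compound 4 is expected to stay small.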

Compound 4, half-maximal effective concentration: < 5020 nM
Compound 4: no number, only a limit (the forecaster's own chance of this, stated with the estimate: 35%); the middle value is on the limit's open side.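

In this assay compound 4 gives < 5020 nM, a limit of the assay and not a number, so none of the steps linking compound 4 to compound 1, compound 2 or compound 3 can be read. The compounds shown leave open whether compound 1, compound 3 and compound 4 differ from one another at all, since their true values stay hidden at one shared limit: the limit of < 5020 nM in this assay, at which 3 of the 4 values shown sit.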